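Sulfonyl aryl swap on a piperidinylpiperidine sulfonamide

This account rests on a few compounds, and the source may have more. Where it says the series, first, only, none or still open, it means among the compounds named here.

Measured so far:
compound 1 `CC1CCN(C2CCN(S(=O)(=O)c3ccc(OCc4ccccc4)cc3)CC2)CC1` — 385 nM
compound 2 `Cc1nc(Cl)sc1S(=O)(=O)N1CCC(N2CCC(C)CC2)CC1` — 1.6 nM

Two compounds share the piperidinylpiperidine sulfonamide core and differ only in the aryl group on the sulfonyl sulfur. In a functional assay on DLD-1 cells (Homo sapiens) for antiproliferative activity, read by CellTiter-Glo, with a stated time of 72 h (a higher number here means a weaker inhibitor, a lower number a stronger inhibitor), compound 2 gives 1.6 nM, the lowest of the two numbers and far beyond the scatter from compound 1, which gives 385 nM.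

Compound 3 `CC1CCN(C2CCN(S(=O)(=O)c3cc(Cl)cc(Cl)c3)CC2)CC1` has not yet been tested. It differs from compound 2 by 3,5-dichlorophenyl in place of 2-chloro-4-methyl-1,3-thiazol-5-yl on a sulfonyl sulfur. Among the measured compounds shown here, no pairwise step is available to anchor this change, so the expectation is a loss beyond the scatter: the step of a 9.4-fold higher number from compound 2 to compound 3 (0.97 log units; beyond the scatter) is estimated as a moderate rise. Compound 3 is therefore expected at 15 nM, within 3 nM to 80 nM.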

Compound 3, half-maximal inhibitory concentration: 3400 nM
For compound 3 the middle estimate is 230-fold (2.36 log units) below the measured one; measured number above the stated range.
By their numbers in this assay, from the lowest: compound 2; then compound 1; then compound 3.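

In this assay, placing 3,5-dichlorophenyl in place of 2-chloro-4-methyl-1,3-thiazol-5-yl on a sulfonyl sulfur gives a 2100-fold higher number from compound 2 to compound 3 (3.33 log units; beyond the scatter), so this position is highly sensitive to the aryl group it carries. Compound 3, at 3400 nM, also stands above compound 1, at 385 nM, so both compounds with a carbon-only aromatic ring here have far higher numbers than compound 2. Nothing at hand explains the size of this step.

The compounds shown do not separate the roles of the ring, its chlorine and its methyl in the 2-chloro-4-methyl-1,3-thiazol-5-yl group. From the compounds shown here alone, how an amine on that ring would read also remains open.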